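Dichlorophenyl on the core: cytotoxicity outlook for compound 4

A few compounds are considered here, and "the series" means these few. Any claim that something is new, unique, unknown or untested is made for them only; others in the source may bear on it.

In an ADME assay on MT4 cells (Homo sapiens) for cytotoxicity (a higher number here means that more compound is tolerated, a lower number that less compound is tolerated), compound 3 `O=C(CSc1snnc1-c1ccccc1)Nc1ccccc1Br` gives > 307000 nM, which is a limit of the assay and not a measured number. Compound 1 `O=C(CSc1snnc1-c1ccccc1)Nc1ccccc1F` gives > 361000 nM in this assay, again only a limit. Compound 2 `O=C(CSc1snnc1-c1ccccc1)Nc1ccccc1Cl` gives > 345000 nM, also a limit. Compound 3 thus stands at the limit of > 307000 nM in this assay, at which 1 of the 3 values shown sits, and the two further values of the series are likewise limits, so no value can be placed above or below another. The steps among the three, a step that the two limits leave unreadable from compound 1 to compound 2, a step that the two limits leave unreadable from compound 1 to compound 3 and a step that the two limits leave unreadable from compound 2 to compound 3, are all left unreadable by the limits on both sides.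

Compound 4 `O=C(CSc1snnc1-c1ccc(Cl)cc1Cl)Nc1ccccc1Br` differs from compound 3 by 2,4-dichlorophenyl in place of phenyl on an aromatic carbon. Within the data shown here, none of the measured steps touches this part of the molecule: each swaps one halogen for another on an aromatic carbon, and each is unreadable in any case, so no measured step bears on the move to compound 4, and no size or direction of step in this assay can be read from the series. The working expectation is that compound 4 is tolerated as compound 3 is, with an at least 1.5-fold lower number from compound 3 to compound 4 (0.18 log units; that floor lies within the scatter) expected to stay within the scatter, while a measured number short of the limit cannot be excluded. Compound 4 is estimated at 200000 nM, within 50000 nM to 400000 nM.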

Compound 4, half-maximal cytotoxic concentration: >= 146000 nM
Compound 4 was reported as a limit; the forecaster's own chance of this, stated with the estimate: 60%; the middle value is on the limit's open side.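

Compound 4 gives >= 146000 nM in this assay, which is a limit of the assay and not a measured number. Among these compounds, compound 3 also stands only at a limit, so no step from it to compound 4 can be read. The compounds shown leave open whether 2,4-dichlorophenyl in place of phenyl alters the tolerated concentration in this assay, and how the four compounds order there.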